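Imine series on a shared core: chloro for methoxy

The compounds below may be only part of what the source reports. "The series", "measured", "known", "first", "only" and "open" are said of these compounds alone.

Three compounds of the series have a number in a functional assay on P388 cells (Mus musculus) for cytotoxicity, read by MTT assay, with a stated time of 72 h; on this read-out lower numbers stand for stronger inhibition and higher numbers for weaker inhibition. Compound 1 `COc1cccc(/C=N/c2c(C)n(C)n(-c3ccccc3)c2=O)c1` gives 105000000 nM and stands lowest of the three. Compound 2 `COc1cc(/C=N/c2c(C)n(C)n(-c3ccccc3)c2=O)ccc1O` gives 316000000 nM and compound 3 `COc1cccc(/C=N/c2c(C)n(C)n(-c3ccccc3)c2=O)c1O` gives 851000000 nM. Both measured steps are hydroxy in place of hydrogen on an aromatic carbon: a 3.0-fold higher number from compound 1 to compound 2 (0.48 log units; beyond the scatter) and an 8.1-fold higher number from compound 1 to compound 3 (0.91 log units; beyond the scatter), each beyond the scatter and each raising the number from compound 1.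

Compound 4 `Cc1c(/N=C/c2cccc(Cl)c2)c(=O)n(-c2ccccc2)n1C` is not yet measured. Relative to compound 1 the change is chloro in place of methoxy on an aromatic carbon, on an aromatic carbon of a six-membered aromatic ring of carbon only, meta to a large group; cut one bond further out it reads 3-methoxyphenyl to 3-chlorophenyl. For the measured compounds named here, neither measured step bears on this change: both concern a hydroxy entering elsewhere, and no pair in the set swaps one substituent for another at the same place. There is therefore no basis for expecting a step beyond the scatter in either direction; the expectation is a number close to that of compound 1, with a wide range.

For compound 4 the estimate is 120000000 nM, between 40000000 nM and 400000000 nM, which is expected to mean a 1.1-fold higher number from compound 1 to compound 4 (0.06 log units; within the scatter).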

Compound 4, half-maximal inhibitory concentration: 550000000 nM
Estimate against measurement, compound 4: 4.6-fold (0.66 log units) below, outside the stated range (above it).
By their numbers in this assay, from the lowest: compound 1; then compounds 2, 4 and 3 (each within the scatter of the next, the first and the last beyond it).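

The exchange of methoxy for chloro at this place is not neutral in this assay (a 5.2-fold higher number from compound 1 to compound 4 (0.72 log units; beyond the scatter)), which shows that this position responds to swapping one substituent for another, something the two hydroxy steps, both concerning a group entering elsewhere, could not show. All three changes from compound 1 now raise the number, so compound 1 keeps the lowest value of the four, while compound 4 sits within the scatter of both compound 2 and compound 3 and cannot be ordered against either. Nothing available on the series accounts for the size of this step, and the reason for it remains unknown.

With only methoxy and chloro compared at this place, the data cannot separate the effect of removing methoxy from that of introducing chloro, and they do not show whether any other substituent here would match or lower the number of compound 1. An amine, a carboxylic acid or a longer alkoxy chain such as ethoxy at the same place would show how far the methoxy result extends, and whether it is specific to that group.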